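The source may hold more compounds than are shown below. What is called first, only, known or untested is meant among the compounds shown, and "the series" means these compounds.

Compound 1 `NC(=S)N/N=C/c1ccc2ccccc2n1` gives > 100000 nM in a functional assay on HL-60 cells (Homo sapiens) for antiproliferative activity, read by sulforhodamine B assay, with a stated time of 72 h (a higher number here means a weaker inhibitor, a lower number a stronger inhibitor), which is a limit of the assay rather than a number.
Compound 2 `COc1ccc(C)cc1NC(=S)N/N=C/c1ccc2ccccc2n1` gives > 100000 nM in this assay, again a limit.
Compound 3 `S=C(N/N=C/c1ccc2ccccc2n1)Nc1ccc(Br)cc1` gives 27500 nM in this assay.

Compound 1 thus stands at the limit, as described by the limit of > 100000 nM in this assay, at which 2 of the 3 values shown sit, whereas compound 3 yields a measured number. Compound 4 `Fc1cccc(NC(=S)N/N=C/c2ccc3ccccc3n2)c1` differs from compound 1 in one place: 3-fluorophenyl in place of hydrogen on an amide-type nitrogen. Going by the values given here, the one measured step that bears on this change is an at least 3.6-fold lower number from compound 1 to compound 3 (0.56 log units; beyond the scatter), where a substituted phenyl entered at the same nitrogen. Compound 2 shows that a differently substituted phenyl at that nitrogen left the value at the limit. The step expected here is an at least 2.0-fold lower number from compound 1 to compound 4 (0.30 log units; that floor lies within the scatter), a modest lowering that may still leave the value at the limit. Compound 4 is expected to give 50000 nM in this assay, within 15000 nM to 150000 nM.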

Compound 4, half-maximal inhibitory concentration: 43800 nM
Beside the measured number, compound 4's estimate is 1.1-fold (0.06 log units) above it; the range from low to high includes it.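

A second substituted phenyl on the amide-type nitrogen now gives a measured number: 3-fluorophenyl in place of hydrogen brings an at least 2.2-fold lower number from compound 1 to compound 4 (0.35 log units; beyond the scatter). Exchanging the group at that nitrogen gives a 1.6-fold higher number from compound 3 to compound 4 (0.20 log units; within the scatter), so 3-fluorophenyl and 4-bromophenyl cannot be told apart here. The step from hydrogen is only a floor, because compound 1 stands at a limit: the limit of > 100000 nM in this assay, at which 2 of the 4 values shown sit.

Going by these compounds, what separates these two compounds from compound 2, which gives > 100000 nM, a limit, stays open. So does whether a phenyl carrying an amine or a carboxylic acid, or a longer chain on that nitrogen, would lower the number further.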